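Halogen swap at the aryl group in the hydrazone series

This account rests on a few compounds, and the source may have more. Where it says the series, first, only, none or still open, it means among the compounds named here.

Within the data shown here, compound 3 `O=C(CSc1ncccn1)N/N=c1/scc(-c2ccc(Br)cc2)n1-c1ccccc1` gives the highest of the three numbers so far in a functional assay on C6 cells (Rattus norvegicus) for cytotoxicity, read by MTT assay, with a stated time of 24 h, tested at 50 ug/mL (a higher number here means a weaker effect of the compound at the concentration tested, a lower number a stronger effect), namely 69%. Compound 2 `O=C(CSc1nnnn1-c1ccccc1)N/N=c1/scc(-c2ccc(Cl)cc2)n1-c1ccccc1` gives 60%, within the scatter of compound 3. Compound 1 `Cc1nnc(SCC(=O)N/N=c2/scc(-c3ccc(Cl)cc3)n2-c2ccccc2)s1` gives 37.9%, beyond the scatter below compound 3. Among the measured compounds shown here, the one measured step, a number 22.1 percentage points higher from compound 1 to compound 2 (beyond the scatter), concerns a different part of the molecule. Compound 4 `O=C(CSc1ncccn1)N/N=c1/scc(-c2ccc(Cl)cc2)n1-c1ccccc1` differs from compound 3 by chloro in place of bromo on an aromatic carbon. For the measured compounds named here, no measured step bears on this change, so no step beyond the scatter is expected in this assay, in either direction. For compound 4 a value of 65% is estimated, within 48% to 82%. The expected step is thus a number 4 percentage points lower from compound 3 to compound 4 (within the scatter).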

Compound 4, a percentage reported as activity, at one concentration (the size of the read-out at that concentration, not a potency): 61.8%
Compound 4: middle estimate off by 3.2 percentage points, on the high side, within the range that was stated.
By their numbers in this assay, from the lowest: compound 1; then compounds 2, 4 and 3 (each within the scatter of the next).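

Chloro in place of bromo on the aromatic carbon gives a number 7.2 percentage points lower from compound 3 to compound 4 (within the scatter) in this assay, so the two halogens are not told apart at this position. With chloro held constant, the group on sulfur separates the compounds only in part: a number 1.8 percentage points higher from compound 2 to compound 4 (within the scatter) stands against a number 23.9 percentage points higher from compound 1 to compound 4 (beyond the scatter). No measured evidence explains either result. Open, as far as these compounds go, is whether an amine or a methoxy group on the same aromatic carbon would give a step beyond the scatter, and whether bromo in place of chloro would shift the 5-methyl-1,3,4-thiadiazol-2-yl compound.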